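Fused-core aryl acids: a chain-extended analogue

The compounds below may be only part of what the source reports. "The series", "measured", "known", "first", "only" and "open" are said of these compounds alone.

Measured to date:
compound 1 `Cc1cc(OCCCC(=O)O)ccc1-c1cc(OC(F)(F)F)ccc1Cl` — > 9950 nM
compound 2 `O=C(O)CCc1cc2cc(-c3cc(OC(F)(F)F)ccc3Cl)ccc2o1` — > 9950 nM
compound 3 `O=C(O)c1cc2cc(-c3cc(OC(F)(F)F)ccc3F)ccc2o1` — > 9950 nM

Among the measured compounds shown here, every number so far is a limit of the assay, not a measured value. In a functional assay on isolated protein for agonist activity at Free fatty acid receptor 1 (Homo sapiens), read by HTRF and inositol phosphate accumulation, with a stated time of 60 min (on this read-out lower numbers stand for an effect already at smaller amounts and higher numbers for an effect only at larger amounts of compound), compound 1 reaches only the limit > 9950 nM. In this assay compound 2 likewise stops at the limit > 9950 nM. The direct parent of the new analogue, compound 3, also gives only the limit > 9950 nM. Compound 3 therefore stands nowhere in particular on the numbers shown: all three values sit together at the same limit, as summarised by the limit of > 9950 nM in this assay, at which 3 of the 3 values shown sit, and no ordering among them can be read.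

The new compound 4 `CC(Cc1cc2cc(-c3cc(OC(F)(F)F)ccc3F)ccc2o1)C(=O)O` differs from compound 3 by 2-carboxypropyl in place of carboxy on an aromatic carbon. For the measured compounds named here, compound 2 already carries an acid chain of similar length on the same part of the core and remains at the limit, so there is no measured step that points toward a gain.

The expectation for compound 4 in this assay is a step of an at least 1.2-fold lower number from compound 3 to compound 4 (0.09 log units; that floor lies within the scatter), most likely again a limit. Compound 4 is estimated at 8000 nM, with a range from 1500 nM to 30000 nM.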

Compound 4, half-maximal effective concentration: > 9950 nM
Compound 4 gave a limit, no number; the forecaster's own chance of this, stated with the estimate: 60%; middle value at least 1.2-fold (0.09 log units) from the limit.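

In this assay, compound 3 and compound 4 both stop at a limit, so the step between them, 2-carboxypropyl in place of carboxy, cannot be read: the limit of > 9950 nM in this assay, at which 4 of the 4 values shown sit.

The compounds shown leave open whether any acid of this series reaches a measurable half-maximal effective concentration, and how carboxy and 2-carboxypropyl compare.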